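Dropping the chloro from compound 3: what to expect

A few compounds are considered here, and "the series" means these few. Any claim that something is new, unique, unknown or untested is made for them only; others in the source may bear on it.

Of the compounds shown here, three sharing one core have been measured in a functional assay on MCF7 cells (Homo sapiens) for antiproliferative activity, read by MTT assay, with a stated time of 24 h, tested at 12.5 uM; a higher number here means a weaker effect of the compound at the concentration tested, a lower number a stronger effect. Compound 1 `OC(CCn1nc2c(Br)c(Br)c(Br)c(Br)c2n1)c1cccc(Br)c1` gives 81%, compound 2 `OC(CCn1nc2c(Br)c(Br)c(Br)c(Br)c2n1)c1ccc(F)cc1` gives 116%, and compound 3 `OC(CCn1nc2c(Br)c(Br)c(Br)c(Br)c2n1)c1cccc(Cl)c1` gives 97%. Compound 3 therefore stands second highest of the three numbers: its nearest neighbour is compound 1, lower by a number 16 percentage points higher from compound 1 to compound 3 (beyond the scatter), and its furthest is compound 2, with a number 19 percentage points lower from compound 2 to compound 3 (beyond the scatter) separating them.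

Compound 4 `OC(CCn1nc2c(Br)c(Br)c(Br)c(Br)c2n1)c1ccccc1` has not been measured in this assay. It differs from compound 3 in a single place: hydrogen in place of chloro on an aromatic carbon.

For the measured compounds named here, no measured step removes a group from the ring without adding another, so none bears directly on this change. The step closest in kind is a number 16 percentage points higher from compound 1 to compound 3 (beyond the scatter), where one substituent on the aromatic carbon was replaced by another and the number rose modestly. The larger rise, a number 35 percentage points higher from compound 1 to compound 2 (beyond the scatter), involved a change of both group and place and is a weaker guide. On that basis a modest rise beyond the scatter is expected, as a number 9 percentage points higher from compound 3 to compound 4 (within the scatter).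

Compound 4 is thus estimated at 106%, within a range from 88% to 124%.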

Compound 4, a percentage reported as activity, at one concentration (the size of the read-out at that concentration, not a potency): 115%
The estimate for compound 4 lay 9 percentage points below the measured number; measured number inside the range.
By their numbers in this assay, from the lowest: compound 1; then compound 3; then compounds 4 and 2 (each within the scatter of the next).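

In this assay, for the compounds shown here, the plain phenyl ring gives the first reading of this place without any halogen: a number 18 percentage points higher from compound 3 to compound 4 (beyond the scatter) and a number 34 percentage points higher from compound 1 to compound 4 (beyond the scatter) show that, on an aromatic carbon meta to a large group, the number falls from hydrogen in compound 4 through chloro in compound 3 to bromo in compound 1. The series therefore has a halogen-free reference, and both the chloro and the bromo compound lie beyond the scatter from it, the bromo by the larger margin. The 4-fluorophenyl group of compound 2 stands apart from this, since a number 1 percentage points lower from compound 2 to compound 4 (within the scatter) leaves compound 2 and compound 4 indistinguishable in this read-out, and no measurement shown here offers a cause for any of these steps.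

The compounds shown leave open whether a fluoro or an iodo at the place of the chloro would fit the same sequence, and whether chloro or bromo at the place of the fluoro in compound 2 would behave as they do here. They also leave open what a methyl, a methoxy or an amine on this ring would do.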